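The source may report more compounds than this note shows. Statements on the series, on what has been measured and on what is new or still open speak of the compounds shown alone.

Measured in a functional assay on COLO 205 cells (Homo sapiens) for antiproliferative activity, read by MTT assay; on this read-out higher numbers stand for weaker inhibition and lower numbers for stronger inhibition:
- compound 1 `O=C(CCl)N1CCCc2cc(S(=O)(=O)N3CC(c4ccccc4)NC3=O)ccc21`: 11200 nM
- compound 2 `O=C1NC(c2ccccc2)CN1S(=O)(=O)c1ccc2c(c1)CCCN2C(=O)C(F)(F)F`: 10700 nM
- compound 3 `CC1(c2ccccc2)CN(S(=O)(=O)c2ccc3c(c2)CCCN3C(=O)C(F)(F)F)C(=O)N1`: > 20000 nM (a limit of the assay, not a number)

Compound 3 has no number in this assay, only a limit: the limit of > 20000 nM in this assay, at which 1 of the 3 values shown sits.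

The next compound is compound 4 `COc1ccc(NC(=O)N2CCCc3cc(S(=O)(=O)N4CC(C)(c5ccccc5)NC4=O)ccc32)cc1`. The change is (4-methoxyphenyl)amino in place of trifluoromethyl on a carbonyl carbon. The methyl on the saturated ring carbon stays in place.

Within the data shown here, two measured steps bear on this. Among the measured compounds shown here, the one swap at this carbonyl carbon, a 1.0-fold lower number from compound 1 to compound 2 (0.02 log units; within the scatter), stayed within the scatter, but it exchanged one small group without a ring for another. The methyl step, an at least 1.8-fold higher number from compound 2 to compound 3 (0.27 log units; that floor lies within the scatter), has a floor within the scatter and concerns a part that does not change here. For the measured compounds named here, no measured compound carries a ring or a hydrogen-bond donor on this carbonyl carbon, so neither step sets the size of the new one.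

A measured number would be expected to lie on the stronger side of the limit, and a further limit remains possible. The expected change is an at least 4.0-fold lower number from compound 3 to compound 4 (0.60 log units; beyond the scatter), a moderate move toward stronger inhibition with wide uncertainty. For compound 4 the estimated value is 5000 nM, with an expected range from 300 nM to 25000 nM.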

Compound 4, half-maximal inhibitory concentration: > 20000 nM
Compound 4 ended at the assay's limit (the forecaster's own chance of this, stated with the estimate: 25%); middle value at least 4.0-fold (0.60 log units) away from the limit.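

In this assay no step from compound 3 to compound 4 can be read, because both compounds give a limit of the assay rather than a number: the limit of > 20000 nM in this assay, at which 2 of the 4 values shown sit.

Left open is whether (4-methoxyphenyl)amino in place of trifluoromethyl on this carbonyl carbon changes the inhibition at all while the methyl stays in place.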